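One amide swap, starting from a limit

This account rests on a few compounds, and the source may have more. Where it says the series, first, only, none or still open, it means among the compounds named here.

Compound 1 (`CN(Cc1ccccc1)C(=O)c1nc(Cc2ccccc2C(F)(F)F)n(C)c(=O)c1O`) is the starting point here, tested in an ADME assay on HepG2 cells (Homo sapiens) for cytotoxicity, in the presence of a further agent that is not named here; on this read-out higher numbers stand for weaker inhibition and lower numbers for stronger inhibition. In that test compound 1 gives > 100000 nM, which is a limit of the assay and not a number. Compound 2 (`CCn1c(Cc2ccccc2C(F)(F)F)nc(C(=O)NCc2ccccc2)c(O)c1=O`) also reads as a limit, at > 100000 nM. Compound 3 (`CC(c1ccccc1C(F)(F)F)c1nc(C(=O)NCc2ccccc2)c(O)c(=O)n1C`) likewise reads as a limit, at > 100000 nM. The whole picture so far is the limit of > 100000 nM in this assay, at which 3 of the 3 values shown sit, so compound 1 cannot be ranked against the other two.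

Compound 4 (`Cn1c(Cc2ccccc2C(F)(F)F)nc(C(=O)Nc2ccccc2)c(O)c1=O`) has not yet been measured. It keeps the shared core and carries anilino in place of benzyl(methyl)amino on a carbonyl carbon. Going by the values given here, no measured pair shows what such a swap does, so the expectation rests on the limits alone. Going by compound 1 and its limit of > 100000 nM, no change beyond the usual scatter is expected in either direction. In this assay the expected step is a number no higher from compound 1 to compound 4 (the limit leaves the size open). For compound 4 the estimate is 100000 nM, with an expected range of 40000 nM to 200000 nM.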

Compound 4, half-maximal inhibitory concentration: > 100000 nM
Compound 4 gave a limit, no number; the forecaster's own chance of this, stated with the estimate: 80%; the middle value sits exactly at the limit.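

No step can be read from compound 1 to compound 4, because both results are limits of the assay and not numbers: the limit of > 100000 nM in this assay, at which 4 of the 4 values shown sit. The compounds shown leave open how strongly any of them acts in this assay and what this amide swap changes there.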